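Same Aryl Swap Tested on a Second Core

This account rests on a few compounds, and the source may have more. Where it says the series, first, only, none or still open, it means among the compounds named here.

Compound 1 `Fc1ccc(C2=NN(C3=NC(c4ccccc4)CS3)C(c3cccc4ccccc34)C2)cc1` gives 12400 nM in a functional assay on HeLa cells (Homo sapiens) for inhibition, read by CCK-8 assay, with a stated time of 48 h; a higher number here means a weaker inhibitor, a lower number a stronger inhibitor.
Compound 2 `Cc1ccc(C2=NN(C3=NC(c4ccccc4)CS3)C(c3cccc4ccccc34)C2)cc1C` gives 1720 nM in this assay.
Compound 3 `O=C1CSC(N2N=C(c3ccc(F)cc3)CC2c2ccc3ccccc3c2)=N1` gives 9170 nM in this assay.

Compound 1 and compound 2 differ in one place: 3,4-dimethylphenyl in place of 4-fluorophenyl on a carbon with a double bond to nitrogen. That change gives a 7.2-fold lower number from compound 1 to compound 2 (0.86 log units; beyond the scatter). Compound 3 shares no counted single difference with compound 1; the difference between the two cores is not broken down here. Against compound 1, compound 3 stands within the scatter, and against compound 2 it stands beyond it.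

Compound 4 `Cc1ccc(C2=NN(C3=NC(=O)CS3)C(c3ccc4ccccc4c3)C2)cc1C` is the unmeasured partner of compound 3, and it carries the same kind of change: 3,4-dimethylphenyl in place of 4-fluorophenyl on a carbon with a double bond to nitrogen. The surroundings are not identical in wording, since here the place lies two ring bonds from the ring atom that bears a group of 6 heavy atoms and two ring bonds from the ring atom that bears a large group, whereas in compound 1 it lies two ring bonds from the ring atom that bears a large group and two ring bonds from the ring atom that bears a naphthalen-1-yl group.

Beside a 7.2-fold lower number from compound 1 to compound 2 (0.86 log units; beyond the scatter), the step from compound 3 to compound 4 is expected to be a 4.0-fold lower number from compound 3 to compound 4 (0.60 log units; beyond the scatter), resting on that single earlier step, which is somewhat discounted since it was seen only once and on a different core. Compound 4 is therefore estimated at 2300 nM in this assay, between 900 nM and 6000 nM.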

Compound 4, half-maximal inhibitory concentration: 860 nM
The estimate for compound 4 lay 2.7-fold (0.43 log units) above the measured number; the measured number lies below the stated range.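

In this assay, the replacement of 4-fluorophenyl by 3,4-dimethylphenyl on the core of compound 3 gives an 11-fold lower number from compound 3 to compound 4 (1.03 log units; beyond the scatter), in the same direction as on the core of compound 1. Within the data shown here, the two steps agree in size as well as direction, so the change carried from one core to the other without a measurable loss: the same change on two cores in this assay, a 7.2-fold lower number (0.86 log units; beyond the scatter) from compound 1 to compound 2 and an 11-fold lower number (1.03 log units; beyond the scatter) from compound 3 to compound 4, 1.5-fold (0.17 log units) apart, within the scatter of two such steps This agreement rests on only two pairs, however, and it shows neither that the change would carry to a further core nor which part of the swap, losing the fluorine or gaining the two methyl groups, produces the lower number.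

The compounds shown leave open whether a single methyl group on the phenyl ring would be enough, and whether a methoxy group, a chlorine or an amine there would give a similar step. They also leave open whether the step would hold on cells other than those of this assay.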